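This account rests on a few compounds, and the source may have more. Where it says the series, first, only, none or still open, it means among the compounds named here.

Compound 2 `CC(C)c1ncncc1-c1nc2cc(F)c(F)cc2n1C1CC1` is the point of departure. In an ADME assay on microsomes from liver (Macaca fascicularis) for metabolic stability, read by LC-MS, with a stated time of 65 min, tested at 1 uM (a lower number here means that less of the compound is left, a higher number that more of the compound is left), compound 2 gives 80%, the second highest of the three numbers measured. Its nearest neighbour is compound 1 `CCc1ncncc1-c1nc2cc(F)c(F)cc2n1C1CC1`, which in this assay gives 78%; the step of a number 2 percentage points higher from compound 1 to compound 2 (within the scatter) cannot be told apart from noise. The furthest is compound 3 `Fc1cc2nc(-c3cncnc3C(F)F)n(C3CC3)c2cc1F`, which in this assay gives 106%, reached by the step of a number 26 percentage points higher from compound 2 to compound 3 (beyond the scatter) and, from compound 1, by the step of a number 28 percentage points higher from compound 1 to compound 3 (beyond the scatter).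

Compound 4 `Fc1cc2nc(-c3cncnc3C(F)(F)F)n(C3CC3)c2cc1F` differs from compound 2 in one place: trifluoromethyl in place of isopropyl on an aromatic carbon. The two steps that bear on this are those leading to compound 3, in which the same position carried difluoromethyl instead of ethyl or isopropyl: a number 28 percentage points higher from compound 1 to compound 3 (beyond the scatter) and a number 26 percentage points higher from compound 2 to compound 3 (beyond the scatter), both modest rises beyond the scatter. Trifluoromethyl is the closest relative of difluoromethyl among the groups seen here, so a rise of similar size is expected in this assay, though no measured step shows trifluoromethyl itself. Compound 4 is therefore expected to give about 100%, in a range from 85% to 115%. The expected step is a number 20 percentage points higher from compound 2 to compound 4 (beyond the scatter).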

Compound 4, percent of the compound remaining: 99%
Compound 4: the middle estimate sits 1 percentage points above what was measured, and the stated range covers the measured number.
By their numbers in this assay, from the lowest: compounds 1 and 2 (each within the scatter of the next); then compounds 4 and 3 (each within the scatter of the next).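

In this assay, the rise seen with difluoromethyl is not unique to that group. Trifluoromethyl on the same aromatic carbon, next to the ring nitrogen, also stands beyond the scatter of both alkyl groups it can replace (a number 19 percentage points higher from compound 2 to compound 4 (beyond the scatter); a number 21 percentage points higher from compound 1 to compound 4 (beyond the scatter)). Replacing the last hydrogen of difluoromethyl with fluoro cannot be told apart from noise (a number 7 percentage points lower from compound 3 to compound 4 (within the scatter)), so among these compounds that hydrogen is not needed for the higher number, and the two fluorinated groups serve equally well here. Nothing measured here explains why these two fluorinated groups differ from ethyl and isopropyl.

Still open, on these data alone, is whether the higher number requires fluorine at this position at all, a question that a methyl, a fluoromethyl, a methoxy or a nitrile in the same place could help to answer. As far as these compounds go, it is also open whether the step from isopropyl to trifluoromethyl would keep its size if the rest of the molecule changed, for example with an amine added to the shared core.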